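The compounds below may be only part of what the source reports. "The series", "measured", "known", "first", "only" and "open" are said of these compounds alone.

Within the data shown here, compound 2 `CCCC(=O)C1=C(C)NC(=O)NC1c1ccoc1` stands highest of the two numbers measured so far: in an assay on membranes from HEK293 cells for displacement of a labelled ligand from adenosine receptor A2b (Homo sapiens), read by scintillation counting, with a stated time of 30 min, tested at 1 uM (a lower number here means less inhibition, a higher number more inhibition at the concentration tested (going by the name of the read-out)), compound 2 gives 22%. Among the measured compounds shown here, compound 1 `CC1=C(C(=O)C2CC2)C(c2ccoc2)NC(=O)N1`, the only other measured compound, in this assay gives 10%. For the measured compounds named here, the single measured step, a number 12 percentage points higher from compound 1 to compound 2 (beyond the scatter), came from putting propyl in place of cyclopropyl on a carbonyl carbon.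

Compound 3 `CC1=C(C(N)=O)C(c2ccoc2)NC(=O)N1` differs from compound 2 by amino in place of propyl on a carbonyl carbon. The measured step bears on this only in that it alters the same carbonyl carbon; it exchanged one chain for another, whereas here the whole propyl is replaced by amino, a change of a different kind. Going by the values given here, no measured step shows what such an exchange does in this assay, so the direction is open and the expectation leans on the low level of both measured numbers. The step from compound 2 is estimated as a number 10 percentage points lower from compound 2 to compound 3 (within the scatter), modest at most. Compound 3 is expected to give 12%, somewhere between 0% and 30%.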

Compound 3, a percentage reported as inhibition, at one concentration (the size of the read-out at that concentration, not a potency): 6%
The estimate for compound 3 lay 6 percentage points above the measured number, within the range that was stated.
By their numbers in this assay, from the lowest: compounds 3 and 1 (each within the scatter of the next); then compound 2.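

Swapping propyl for amino gives, in this assay, a number 16 percentage points lower from compound 2 to compound 3 (beyond the scatter), so an open carbon chain is no longer the only kind of group tested at this position, and this non-carbon replacement loses the higher number seen with propyl. Amino in place of cyclopropyl gives a number 4 percentage points lower from compound 1 to compound 3 (within the scatter), so these two groups cannot be told apart here, while propyl is the only one of the three whose steps to both others lie beyond the scatter. No supporting measurement explains these differences.

Among these compounds, all three compounds were measured at only the one concentration tested, so it is open whether any group here can give a much higher number. A butyl chain or a methylamino group on the same carbonyl carbon would show whether the higher number with propyl extends to a longer chain or to a substituted amine.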